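Sugar stereocentre inversion on a linear RGD-type peptide conjugate

The compounds below may be only part of what the source reports. "The series", "measured", "known", "first", "only" and "open" are said of these compounds alone.

Measured so far:
Compound 1 `N=C(N)NCCC[C@H](N)C(=O)NCC(=O)N[C@@H](CC(=O)O)C(=O)N[C@@H](CSCc1cn(CCO[C@H]2O[C@H](CF)[C@@H](O)[C@H](O)[C@H]2O)nn1)C(=O)O`: 26000 nM
Compound 2 `N=C(N)NCCC[C@H](N)C(=O)NCC(=O)N[C@@H](CC(=O)O)C(=O)N[C@@H](CSCc1cn(CCO[C@@H]2O[C@H](CO)[C@H](O)[C@H](O)[C@H]2O)nn1)C(=O)O`: 23000 nM
Compound 3 `N=C(N)NCCC[C@@H]1NC(=O)[C@H](CSCc2cn(CCO[C@@H]3O[C@H](CF)[C@@H](O)[C@H](O)[C@H]3O)nn2)NC(=O)[C@H](Cc2ccccc2)NC(=O)[C@H](CC(=O)O)NC(=O)CNC1=O`: 148000 nM

In a functional assay on a cell-free system (Platelet, plasma, Homo sapiens) for inhibition, with a stated time of 10 min, at 37 degrees C (on this read-out higher numbers stand for weaker inhibition and lower numbers for stronger inhibition), compound 1 gives 26000 nM, the second highest of the three numbers; the nearest is compound 2 with 23000 nM, while the cyclic compound 3 stands furthest away with 148000 nM, a higher number beyond the scatter. Compound 4 `N=C(N)NCCC[C@H](N)C(=O)NCC(=O)N[C@@H](CC(=O)O)C(=O)N[C@@H](CSCc1cn(CCO[C@H]2O[C@H](CF)[C@@H](O)[C@H](O)[C@@H]2O)nn1)C(=O)O` is not yet measured. It differs from compound 1 in this way: the two compounds have the same atoms and bonds; at least one stereo element is drawn with a configuration in one of them and without one in the other: 1 of 9 stereo elements differ; a stereocentre at a saturated ring carbon is drawn R in compound 1 and S in compound 4. Within the data shown here, no two measured compounds differ only by such an inversion, so the closest guide is the exchange of one sugar for another on the same oxygen, a 1.1-fold lower number from compound 1 to compound 2 (0.05 log units; within the scatter), a change within the scatter. Among the measured compounds shown here, the sugar portion therefore appears to matter little on this read-out among the linear compounds, with no compound going against that. For compound 4 the expected step is a 1.0-fold higher number from compound 1 to compound 4 (0.02 log units; within the scatter), none beyond the scatter. The estimate for compound 4 in this assay is 27000 nM, with a range from 13000 nM to 56000 nM.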

Compound 4, half-maximal inhibitory concentration: 23500 nM
Estimate against measurement, compound 4: 1.1-fold (0.06 log units) above; measured number inside the range.
By their numbers in this assay, from the lowest: compounds 2, 4 and 1 (each within the scatter of the next); then compound 3.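

In this assay, inversion at a saturated ring carbon of the sugar gives a 1.1-fold lower number from compound 1 to compound 4 (0.04 log units; within the scatter), so this position now has a direct reading of its own rather than one inferred from a sugar exchange. The exchange of sugars on the same oxygen gives a 1.0-fold higher number from compound 2 to compound 4 (0.01 log units; within the scatter), so neither change takes the linear conjugates beyond the scatter. Reading the first step as a clean inversion carries one caveat: the fact that one of compounds 1 and 4 is drawn with a defined configuration and the other without, at the place where they differ.

On these data alone, whether the same inversion also stays within the scatter on the cyclic core of compound 3 remains open. Also open, as far as these compounds go, is what an amine or a carboxylic acid would do at this ring carbon in place of the hydroxyl, a change of group rather than of configuration.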